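The compounds below may be only part of what the source reports. "The series", "measured", "known", "first", "only" and "open" are said of these compounds alone.

Compound 1, `Oc1ccccc1-c1cc(-c2ccc(C(F)(F)F)cc2)cc(-c2ccccc2O)n1`: in a functional assay on HCT-15 cells (Homo sapiens) for inhibition (a lower number here means a stronger inhibitor, a higher number a weaker inhibitor), compound 1 gives > 50000 nM, which is a limit of the assay.
Compound 2, `Oc1ccc(-c2cc(-c3ccc(C(F)(F)F)cc3)cc(-c3ccccc3O)n2)cc1`: in this assay compound 2 gives > 50000 nM, again a limit.

Compound 2 therefore stands at the edge of what this assay can report, as does compound 1: the limit of > 50000 nM in this assay, at which 2 of the 2 values shown sit. Among the compounds with values here, the single measured step, a step that the two limits leave unreadable from compound 1 to compound 2, cannot be read from two limits. Compound 3, `Oc1ccc(-c2cc(-c3ccc(OC(F)(F)F)cc3)cc(-c3ccccc3O)n2)cc1`, differs from compound 2 by trifluoromethoxy in place of trifluoromethyl on an aromatic carbon. Within the data shown here, no measured step bears on this change, so the expected step of a number no higher from compound 2 to compound 3 (the limit leaves the size open) is an estimate of no change beyond the scatter. Compound 3 is expected at 50000 nM, within 15000 nM to 200000 nM, most likely reported as a limit again.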

Compound 3, half-maximal inhibitory concentration: > 50000 nM
Compound 3: only a limit was reported; the forecaster's own chance of this, stated with the estimate: 80%; the middle value sits exactly at the limit.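

Within the data shown here, compound 2 and compound 3 both give only a limit in this assay, so no step between them can be read: the limit of > 50000 nM in this assay, at which 3 of the 3 values shown sit. Still open, from the compounds shown here alone, is how strong any of the three compounds truly is, and whether any change to the shared core would give a readable value.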